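The source may hold more compounds than are shown below. What is called first, only, known or untested is meant among the compounds shown, and "the series" means these compounds.

Measured in a functional assay on the whole organism for inhibition, with Rattus norvegicus as the target, read by cytopathic effect and paw edema, at a dose of 100 mg/kg by the oral route; on this read-out lower numbers stand for less inhibition and higher numbers for more inhibition at the one dose given (going by the name of the read-out):
compound 1 `O=C(Nc1ccccn1)c1c(O)c2cccnc2n(-c2ccccc2)c1=O`: 14.6%
compound 2 `Cc1ccc(NC(=O)c2c(O)c3cccnc3n(-c3ccccc3)c2=O)cc1`: 2.2%
compound 3 `COc1cccc(NC(=O)c2c(O)c3cccnc3n(-c3ccccc3)c2=O)c1`: 20.7%

Compound 1 stands second highest of the three numbers in this assay. Its nearest neighbour is compound 3, and the step of a number 6.1 percentage points higher from compound 1 to compound 3 (within the scatter) lies within the scatter, so no order between compound 1 and compound 3 can be read from these two values. The step of a number 12.4 percentage points lower from compound 1 to compound 2 (beyond the scatter) lies beyond the scatter, as does the step of a number 18.5 percentage points higher from compound 2 to compound 3 (beyond the scatter), which is the largest of the three.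

Compound 4 `O=C(Nc1cccnc1)c1c(O)c2cccnc2n(-c2ccccc2)c1=O` differs from compound 1 in one place: pyridin-3-yl in place of pyridin-2-yl on an amide-type nitrogen. Going by the values given here, no measured step covers this change. The two steps out of compound 1, a number 12.4 percentage points lower from compound 1 to compound 2 (beyond the scatter) and a number 6.1 percentage points higher from compound 1 to compound 3 (within the scatter), each replace the pyridin-2-yl group with 4-methylphenyl or 3-methoxyphenyl rather than with another pyridyl group, and they run in opposite directions. With nothing comparable to go by, the expected step in this assay is small and of no fixed direction, remaining within the scatter; the estimated step is a number 0.6 percentage points lower from compound 1 to compound 4 (within the scatter). Compound 4 is therefore estimated at 14% in this assay, with an expected range from 2% to 28%.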

Compound 4, a percentage reported as inhibition, in the whole organism at one dose (the size of the read-out at that dose, not a potency): 30.8%
Compound 4: the middle estimate sits 16.8 percentage points below what was measured; measured number outside the range, above it.
By their numbers in this assay, from the lowest: compound 2; then compounds 1 and 3 (each within the scatter of the next); then compound 4.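

In this assay this position responds to the place of the ring nitrogen alone: moving from pyridin-2-yl to pyridin-3-yl gives a number 16.2 percentage points higher from compound 1 to compound 4 (beyond the scatter) and leaves the atom, donor and acceptor counts unchanged. The same group also gives a number 10.1 percentage points higher from compound 3 to compound 4 (beyond the scatter) and a number 28.6 percentage points higher from compound 2 to compound 4 (beyond the scatter) so compound 4 holds the highest number of the four and pyridin-3-yl reads above both substituted phenyl groups shown. No measured evidence accounts for the difference between the two pyridyl groups.

The compounds shown leave open how pyridin-4-yl would read on the same amide-type nitrogen, and whether a saturated amine such as piperidin-4-yl or a phenyl group carrying a carboxylic acid would hold this level. On these data alone, whether this order persists at other doses also remains open, since each number comes from one dose.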